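Methyl for trifluoromethyl: expectation for compound 4

The source may report more compounds than this note shows. Statements on the series, on what has been measured and on what is new or still open speak of the compounds shown alone.

Measured in a functional assay on NUGC-3 cells (Homo sapiens) for antiproliferative activity, read by sulforhodamine B assay; on this read-out higher numbers stand for weaker inhibition of growth and lower numbers for stronger inhibition of growth:
compound 1 `Cc1cc(C)c2sc(NC(=O)c3ccc(C(F)(F)F)cc3)nc2c1`: 1.4 ug/mL
compound 2 `COc1ccc2sc(NC(=O)c3ccc(C(F)(F)F)cc3)nc2c1`: > 10 ug/mL, a limit of the assay rather than a number
compound 3 `COc1ccc(C(=O)Nc2nc3c(OC)cccc3s2)cc1`: 3.46 ug/mL

Compound 2 stands at the limit of > 10 ug/mL in this assay, at which 1 of the 3 values shown sits, so only a limit is known for it. Among the compounds with values here, compound 1 and compound 3 give numbers in this assay; no one-point step links either to compound 2. Compound 4 `COc1ccc2sc(NC(=O)c3ccc(C)cc3)nc2c1` differs from compound 2 by methyl in place of trifluoromethyl on an aromatic carbon. Within the data shown here, no measured step of this kind exists here, so its size is a guess; a change not clearly beyond the scatter is expected, with the result likely to stay near the limit. Compound 4 is estimated at 9 ug/mL, range 3 ug/mL to 30 ug/mL, which is expected to mean a step of an at least 1.1-fold lower number from compound 2 to compound 4 (0.04 log units; that floor lies within the scatter).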

Compound 4, concentration for 50% growth inhibition: > 10 ug/mL
Compound 4 ended at the assay's limit (the forecaster's own chance of this, stated with the estimate: 55%); middle value at least 1.1-fold (0.04 log units) away from the limit.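

Within the data shown here, compound 2 and compound 4 both rest at a limit rather than a number, so no step between them can be read: the limit of > 10 ug/mL in this assay, at which 2 of the 4 values shown sit.
Going by these compounds, whether methyl in place of trifluoromethyl changes growth inhibition at all remains open.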